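Inverting one ring stereocentre in a cyclopropane amide

The compounds below may be only part of what the source reports. "The series", "measured", "known", "first", "only" and "open" are said of these compounds alone.

Two measured compounds share a trimethoxyphenyl cyclopropane carrying a chloroanilide. Compound 1 `COc1cc([C@H]2C[C@]2(CO)C(=O)Nc2ccccc2Cl)cc(OC)c1OC` gives 40200 nM in a functional assay on SW480 cells (Homo sapiens) for cytotoxicity, read by MTT assay, with a stated time of 48 h; a lower number here means a stronger inhibitor, a higher number a weaker inhibitor. Compound 2 `CCOC(=O)[C@@]1(C(=O)Nc2ccccc2Cl)C[C@H]1c1cc(OC)c(OC)c(OC)c1` gives 30100 nM in this assay; its number and that of compound 1 lie within the usual scatter of each other, so neither can be called stronger. Compound 3 `CCOC(=O)[C@]1(C(=O)Nc2ccccc2Cl)C[C@H]1c1cc(OC)c(OC)c(OC)c1` is the next compound: the two compounds have the same atoms and bonds and differ only in configuration as drawn: 1 of 2 stereo elements differ; a stereocentre at a saturated ring carbon is drawn S in compound 2 and R in compound 3. For the measured compounds named here, with no comparable step between measured compounds to lean on, the expected step of a 1.0-fold lower number from compound 2 to compound 3 (0.00 log units; within the scatter) is none beyond the scatter. Compound 3 is therefore estimated at 30000 nM, within a range from 10000 nM to 90000 nM.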

Compound 3, half-maximal inhibitory concentration: 25600 nM
For compound 3 the middle estimate is 1.2-fold (0.07 log units) above the measured one, within the range that was stated.
By their numbers in this assay, from the lowest: compounds 3, 2 and 1 (each within the scatter of the next).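

This is the first pair in the set that differs in one place, and it isolates a single feature: the fact that compounds 2 and 3 differ only in the configuration as drawn

In this assay, inverting this saturated ring carbon gives a 1.2-fold lower number from compound 2 to compound 3 (0.07 log units; within the scatter), so the drawn S and R forms cannot be told apart at this stereocentre, at least with the ethyl ester in place.

The compounds shown leave open whether inverting the other stereocentre would matter. They also leave open whether this inversion would remain without a clear effect if a carboxylic acid replaced the ethyl ester.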